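Methyl on the Exocyclic Amine of a Bicyclic Triphosphate

A few compounds are considered here, and "the series" means these few. Any claim that something is new, unique, unknown or untested is made for them only; others in the source may bear on it.

Measured so far:
compound 1 `Nc1ncnc2c1ncn2C1C(O)C(O)C2(COP(=O)(O)OP(=O)(O)OP(=O)(O)O)CC12`: 52 nM
compound 2 `CSc1nc(N)c2ncn(C3C(O)C(O)[C@@]4(COP(=O)(O)OP(=O)(O)OP(=O)(O)O)C[C@@H]34)c2n1`: 23 nM
compound 3 `Nc1nc(Cl)nc2c1ncn2C1C(O)C(O)[C@@]2(COP(=O)(O)OP(=O)(O)OP(=O)(O)O)C[C@@H]12`: 7 nM

The three compounds share a core and were tested in an assay on cells with P2Y purinoceptor 1 (Homo sapiens) as the target, read by inositol phosphate accumulation; a lower number here means that less compound is needed, a higher number that more compound is needed for the effect. Compound 1 gives 52 nM, compound 2 gives 23 nM, and compound 3 gives 7 nM. Among the compounds with values here, compound 3 stands lowest of the three; compound 2 is nearest, and the one measured step, a 3.3-fold lower number from compound 2 to compound 3 (0.52 log units; beyond the scatter), is modest but beyond the scatter. Compound 1, with hydrogen where compounds 2 and 3 carry their substituent, lies furthest away.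

Compound 4 `CNc1nc(Cl)nc2c1ncn2C1C(O)C(O)[C@@]2(COP(=O)(O)OP(=O)(O)OP(=O)(O)O)C[C@@H]12` is not yet measured. It differs from compound 3 by methyl in place of hydrogen on a nitrogen on an aromatic ring; cut one bond further out, the change reads amino to methylamino. Within the data shown here, none of the measured steps touches this nitrogen: the only step, from a methylsulfanyl to a chloro on an aromatic carbon, leaves the amine untouched. Among the measured compounds shown here, there is therefore no measured step that bears on the change, and the expectation for compound 4 in this assay rests on compound 3 alone. Compound 4 is expected to give about 7 nM, with a range from 2 nM to 25 nM. The step this implies, no change at the digits printed from compound 3 to compound 4 (within the scatter), is expected to lie within the scatter.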

Compound 4, half-maximal effective concentration: 9 nM
Compound 4: the middle estimate sits 1.3-fold (0.11 log units) below what was measured, and the stated range covers the measured number.
By their numbers in this assay, from the lowest: compounds 3 and 4 (each within the scatter of the next); then compound 2; then compound 1.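

In this assay the change from amino to methylamino gives a 1.3-fold higher number from compound 3 to compound 4 (0.11 log units; within the scatter), so with chloro held in place, compound 3 and compound 4 cannot be told apart. Within the data shown here, this is the first view of the nitrogen on the aromatic ring, since the earlier step changed only the group on an aromatic carbon and left the amine as it was; it shows that, in this pair, one hydrogen of the amine can give way to methyl without a shift beyond the scatter. Nothing measured here accounts for why the number holds.

The compounds shown leave open whether a larger group on this nitrogen, such as ethyl, a longer chain or a cyclopropyl ring, or a second methyl giving dimethylamino, would also leave the number within the scatter. They also leave open whether methylamino would behave the same way with methylsulfanyl in place of chloro, as in compound 2, or with hydrogen there, as in compound 1, since this single pair speaks only for the chloro series.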